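A few compounds are considered here, and "the series" means these few. Any claim that something is new, unique, unknown or untested is made for them only; others in the source may bear on it.

In a functional assay (blood) for inhibition, with Homo sapiens as the target (on this read-out higher numbers stand for weaker inhibition and lower numbers for stronger inhibition), compound 2 `CC(C)(C)Sc1c(CC(C)(C)C(=O)O)n(Cc2ccc(Cl)cc2)c2ccc(OCc3ccc4cc(F)ccc4n3)cc12` gives 880 nM and compound 3 `COc1ccc2nc(COc3ccc4c(c3)c(SC(C)(C)C)c(CC(C)(C)C(=O)O)n4Cc3ccc(Cl)cc3)sc2c1` gives 670 nM as values within the scatter of each other. Compound 1 `CC(C)(C)Sc1c(CC(C)(C)C(=O)O)n(Cc2ccc(Cl)cc2)c2ccc(CCc3ccc4ccccc4n3)cc12` shows > 3000 nM as a limit of the assay and not a number. Compound 4 `CC(C)(C)Sc1c(CC(C)(C)C(=O)O)n(Cc2ccc(Cl)cc2)c2ccc(OCc3nc4ccccc4o3)cc12` is not yet measured and differs from compound 2 by one swap (1,3-benzoxazol-2-yl in place of 6-fluoroquinolin-2-yl on a saturated chain carbon bound to an oxygen on an aromatic ring) with 1,3-benzoxazol-2-yl in place of 6-fluoroquinolin-2-yl on a saturated chain carbon bound to an oxygen on an aromatic ring. The measured step that bears on it is a 1.3-fold lower number from compound 2 to compound 3 (0.12 log units; within the scatter) and it put 6-methoxy-1,3-benzothiazol-2-yl in that same place without leaving the scatter. The expected move is therefore a 1.1-fold lower number from compound 2 to compound 4 (0.04 log units; within the scatter) in this assay with no change beyond the scatter. The estimated value for compound 4 is 800 nM and the expected range runs from 300 nM up to 2200 nM for repeat measurements.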

Compound 4, half-maximal inhibitory concentration: 2500 nM
The estimate for compound 4 lay 3.1-fold (0.49 log units) below the measured number; measured number above the stated range.
By their numbers in this assay, from the lowest: compounds 3 and 2 (each within the scatter of the next); then compound 4. At a limit, above all of these: compound 1.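

In this assay, the group on this saturated chain carbon proves to matter: 1,3-benzoxazol-2-yl gives a 2.8-fold higher number from compound 2 to compound 4 (0.45 log units; beyond the scatter) and a 3.7-fold higher number from compound 3 to compound 4 (0.57 log units; beyond the scatter), whereas the earlier swap gave a 1.3-fold lower number from compound 2 to compound 3 (0.12 log units; within the scatter). The three groups are therefore not interchangeable at this place. Compound 1 stands at a limit and not a number: the limit of > 3000 nM in this assay, at which 1 of the 4 values shown sits. The step that can be given from it is an at least 1.2-fold lower number from compound 1 to compound 4 (0.07 log units; that floor lies within the scatter), so this comparison offers only a floor.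

Going by these compounds, what 1,3-benzothiazol-2-yl without a methoxy group or 6-methoxy-1,3-benzoxazol-2-yl would give here stays open. The compounds shown therefore cannot separate the effect of changing the ring from that of the missing methoxy group.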